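Adding an Acetyl Group to Compound 1

A few compounds are considered here, and "the series" means these few. Any claim that something is new, unique, unknown or untested is made for them only; others in the source may bear on it.

Three compounds have values in an ADME assay on HEp-2 cells (Homo sapiens) for cytotoxicity (on this read-out higher numbers stand for lower toxicity in this test and lower numbers for higher toxicity in this test), so far:
- compound 1 `C=C(C)n1c(=O)n(Cc2nc3ccccc3n2CCC(C)C)c2ccccc21` gives 24600 nM
- compound 2 `CC(C)CCn1c(Cn2c(=O)n(C(C)C)c3ccccc32)nc2ccc(C(=O)O)cc21` gives 125000 nM
- compound 3 `COC(=O)c1cccc2nc(Cn3c(=O)n(C(C)C)c4ccccc43)n(CCC(C)C)c12` gives 25300 nM

Compound 1 stands level with compound 3, the two being within the scatter of each other. Compound 2 reads higher than compound 1, and that gap lies beyond the scatter. The next compound to be measured is compound 4 (`C=C(C)n1c(=O)n(Cc2nc3cc(C(C)=O)ccc3n2CCC(C)C)c2ccccc21`), which keeps the core of compound 1 and has acetyl in place of hydrogen on an aromatic carbon. This carbon belongs to a six-membered aromatic ring of carbon only, part of a fused system of two rings.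

Within the data shown here, no two measured compounds differ in one place, so the data hold no direct step for this change, and any expectation is a loose one. Compound 3 carries a methyl ester and gives 25300 nM in this assay, level with compound 1. Among the measured compounds shown here, compound 2, with its carboxylic acid, is the only high reading. Compound 4 has no acid, so it is expected to stay near compound 1. The estimate is a 1.1-fold higher number from compound 1 to compound 4 (0.06 log units; within the scatter) and no step beyond the scatter is expected. Compound 4 is estimated at 28000 nM (expected range 12000 nM to 65000 nM).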

Compound 4, half-maximal cytotoxic concentration: 740 nM
Estimate against measurement, compound 4: 38-fold (1.58 log units) above; the measured number lies below the stated range.
By their numbers in this assay, from the lowest: compound 4; then compounds 1 and 3 (each within the scatter of the next); then compound 2.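

In this assay, among these compounds, the first step between two measured compounds that differ in one place is a large one: acetyl in place of hydrogen on an aromatic carbon gives a 33-fold lower number from compound 1 to compound 4 (1.52 log units; beyond the scatter) and so moves the reading toward higher toxicity in this test. Among the compounds shown here, the earlier compounds held no such step, so this is the first sign that this place on the six-membered aromatic ring of carbon only is not indifferent here, and that a group of just 3 heavy atoms entering there can shift the number far beyond the scatter. The data offer no explanation for the size of this step.

A single step cannot tell whether the shift belongs to acetyl itself or would appear with other groups on the same carbon of the core of compound 1, such as an amine, a nitrile or a hydroxyl group. Also open, on these data alone, is whether acetyl on another carbon of that ring would give a step of similar size, and whether the same change on a different core would do so.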